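Taking the benzyl group off compound 1

The source may report more compounds than this note shows. Statements on the series, on what has been measured and on what is new or still open speak of the compounds shown alone.

In a functional assay on HCT-116 cells (Homo sapiens) for cytotoxicity, read by hypoxanthine incorporation, with a stated time of 72 h, tested at 10 uM (a higher number here means more inhibition of growth at the concentration tested, a lower number less inhibition of growth), compound 1 `CC(C)[C@H]1NC(=O)[C@@H](Cc2ccccc2)N(C)C(=O)[C@H](Cc2ccccc2)NC(=O)[C@H](COCc2ccccc2)NC(=O)[C@H](CC2CCCCC2)NC1=O` gives 93% and stands highest of the two numbers measured, with compound 2 `CC(C)[C@H]1NC(=O)[C@@H](Cc2ccccc2)NC(=O)[C@H](Cc2ccccc2)NC(=O)[C@H](COCc2ccccc2)NC(=O)[C@H](CC2CCCCC2)NC1=O` giving 10% as the only other. Compound 3 `CC(C)[C@H]1NC(=O)[C@@H](Cc2ccccc2)N(C)C(=O)[C@H](Cc2ccccc2)NC(=O)[C@H](CO)NC(=O)[C@H](CC2CCCCC2)NC1=O` carries the change hydrogen in place of benzyl on an oxygen on a saturated carbon and so has hydrogen in place of benzyl on an oxygen on a saturated carbon. Going by the values given here, the one measured step of a number 83 percentage points lower from compound 1 to compound 2 (beyond the scatter) is large but lies at another place, hydrogen in place of methyl on an amide-type nitrogen in a ring. Among the compounds with values here, it shows only that a single change can move this number far, so a sizeable fall in this assay is expected, though no measurement tests this place. The estimated step is a number 48 percentage points lower from compound 1 to compound 3 (beyond the scatter) with wide uncertainty. Compound 3 is expected at 45% within a range of 10% to 85% in this estimate.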

Compound 3, percent growth inhibition at one concentration: 18%
For compound 3 the middle estimate is 27 percentage points above the measured one; low and high end bracket the measured number.
By their numbers in this assay, from the lowest: compounds 2 and 3 (each within the scatter of the next); then compound 1.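

At this position, the oxygen on a saturated carbon, this assay gives a number 75 percentage points lower from compound 1 to compound 3 (beyond the scatter) for the change from benzyloxy to hydroxy. The amide-type nitrogen in a ring is therefore not the only place in the core of compound 1 where a single change moves this number far. No evidence at hand bears on why this number falls. The compounds shown leave open how a methyl or a longer alkyl chain on this oxygen would read, and thus whether the benzyl group itself is required.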